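The compounds below may be only part of what the source reports. "The series", "measured", "known", "first", "only" and "open" are said of these compounds alone.

Compound 1 `CCCc1c(OCCCCOc2ccc(-c3nn[nH]n3)cc2)ccc2c1ccn2CC(C)(C)C` is one of three compounds on a shared core that have been measured in a functional assay for binding affinity to metabotropic glutamate receptor 2 (Homo sapiens), read by GTPgammaS binding, with a stated time of 1 h, at 30 degrees C; a higher number here means that more compound is needed for the effect, a lower number that less compound is needed; in that assay compound 1 gives 559 nM. Compound 2 `CCCc1c(OCCCCOc2ccc(-c3nn[nH]n3)cc2)ccc2c1ccn2CCC` gives 652 nM and compound 3 `CCCc1c(OCCCCOc2ccc(-c3nn[nH]n3)cc2)ccc2c1ccn2CC1CCCCC1` gives 228 nM. Among these three numbers compound 1 stands second highest: the step of a 1.2-fold higher number from compound 1 to compound 2 (0.07 log units; within the scatter) lies within the scatter, whereas a 2.5-fold lower number from compound 1 to compound 3 (0.39 log units; beyond the scatter) and a 2.9-fold lower number from compound 2 to compound 3 (0.46 log units; beyond the scatter) are modest steps beyond it. All three measured steps concern the group on a saturated chain carbon bound to an aromatic nitrogen. Compound 4 `Cc1c(OCCCCOc2ccc(-c3nn[nH]n3)cc2)ccc2c1ccn2CC(C)(C)C` differs from compound 1 at another place: hydrogen in place of ethyl on a saturated chain carbon bound to an aromatic carbon. Within the data shown here, no measured pair differs at that place, so none of the measured steps bears directly on it; the measured steps show only that the series so far moves within a modest span. With no direct guide, the step from compound 1 to compound 4 is estimated as a 2.1-fold higher number from compound 1 to compound 4 (0.33 log units; beyond the scatter), a rise in the number, held with low confidence. Compound 4 is therefore expected to give about 1200 nM in this assay, within a range from 400 nM to 4000 nM.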

Compound 4, half-maximal effective concentration: 1070 nM
Compound 4: the middle estimate sits 1.1-fold (0.05 log units) above what was measured, within the range that was stated.
By their numbers in this assay, from the lowest: compound 3; then compounds 1, 2 and 4 (each within the scatter of the next).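

Among these compounds, the change on a saturated chain carbon bound to an aromatic carbon can now be read directly for the first time: in this assay, propyl to methyl gives a 1.9-fold higher number from compound 1 to compound 4 (0.28 log units; within the scatter) and so stays within the usual variation of the measurement. Losing the ethyl and its 2 carbon atoms therefore produces no step that can be separated from the scatter, and compounds 1 and 4 cannot be placed in order. Nothing given here explains this result.

The compounds shown leave open how a longer chain such as butyl, or an amine or a carboxylic acid, would read at this place. They also do not show whether propyl and methyl would stay as close with the cyclohexyl group of compound 3 on the nitrogen side.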